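The source may report more compounds than this note shows. Statements on the series, on what has been measured and on what is new or still open speak of the compounds shown alone.

Of the compounds shown here, two built on the same core have been tested so far. Compound 1, `COc1ccc(-n2cc(C(=O)c3cc(OC)c(OC)c(OC)c3)c(-c3ccccc3)c2)cc1`, carries a phenyl group and a 4-methoxyphenyl group on its five-membered aromatic ring, and in a functional assay on MCF7 cells (Homo sapiens) for cytotoxicity, read by MTT assay, with a stated time of 96 h (on this read-out higher numbers stand for weaker inhibition and lower numbers for stronger inhibition), compound 1 gives 120 nM. Compound 2, `COc1cc(C(=O)c2cn(-c3ccccc3)cc2-c2ccccc2C)cc(OC)c1OC`, carries a phenyl group and a 2-methylphenyl group instead, and in this assay compound 2 gives 190 nM. Compound 2 has the higher of the two numbers, but the gap to compound 1 lies within the usual scatter, so the two readings cannot be told apart with confidence.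

Compound 3, `COc1ccc(-c2cn(-c3ccccc3)cc2C(=O)c2cc(OC)c(OC)c(OC)c2)cc1`, is the next compound to be measured. It differs from compound 2 in a single place: 4-methoxyphenyl in place of 2-methylphenyl on an aromatic carbon. The 4-methoxyphenyl group already appears in compound 1, though there it sits on the ring nitrogen rather than on an aromatic carbon.

Among the compounds with values here, with only two measured values and no step between them beyond the scatter, the change is expected to move the number little, if at all: the step of a 1.3-fold lower number from compound 2 to compound 3 (0.10 log units; within the scatter) is estimated to stay within the scatter. Compound 3 is expected to give about 150 nM, between 60 nM and 400 nM.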

Compound 3, half-maximal inhibitory concentration: 70 nM
Compound 3: the middle estimate sits 2.1-fold (0.33 log units) above what was measured; the measured number falls inside the stated range.
By their numbers in this assay, from the lowest: compounds 3, 1 and 2 (each within the scatter of the next, the first and the last beyond it).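

In this assay, within the data shown here, the aromatic carbon two ring bonds from the ring nitrogen proves sensitive to the group it carries: 4-methoxyphenyl in place of 2-methylphenyl gives a 2.7-fold lower number from compound 2 to compound 3 (0.43 log units; beyond the scatter) and is the first step to clear the usual scatter, though only modestly. The swap alters two features at once, replacing the methyl with a methoxy and changing where that small group stands on the phenyl ring, so the step cannot be credited to either feature alone. No separate measurement is available to explain why the number falls.

The compounds shown leave these two features tangled: 4-methylphenyl and 2-methoxyphenyl at this carbon would each change only one of them relative to compound 2 or compound 3, and so could show which feature carries the step. Going by these compounds, it also remains open whether this carbon would accept a group of a different kind, such as a 4-aminophenyl or 4-carboxyphenyl group, or a simple ethyl chain in place of the six-membered aromatic ring.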